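Swapping a Cyclohexyl Ring for Phenyl on the Shared Core

The compounds below may be only part of what the source reports. "The series", "measured", "known", "first", "only" and "open" are said of these compounds alone.

Measured compounds:
compound 1 `COc1ccccc1-c1nnc2sc(/C=C/c3ccco3)nn12`: 75%
compound 2 `C(=C/c1nn2c(C3CCCCC3)nnc2s1)\c1ccco1`: 68%

Of the compounds shown here, two have been tested in an assay for inhibition of histone-lysine N-methyltransferase, H3 lysine-79 specific (Homo sapiens), read by scintillation counting, with stated times of 15 min and 60 min, tested at 50 uM, in the presence of a further agent that is not named here; on this read-out higher numbers stand for a stronger effect at the one concentration tested and lower numbers for a weaker effect. Compound 1 gives 75%, and compound 2 gives 68%. Compound 2 stands lowest of the two numbers, but its nearest neighbour, compound 1, sits within the scatter of repeated measurements, so the two cannot be ranked against each other.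

The next compound, compound 3 `C(=C/c1nn2c(-c3ccccc3)nnc2s1)\c1ccco1`, differs from compound 2 in one place: phenyl in place of cyclohexyl on an aromatic carbon. Within the data shown here, no pair of measured compounds differing in one place has been recorded, so there is no directly comparable step to lean on. What can be said is that compound 1, carrying a different group at that carbon, lands within the scatter of compound 2. On that basis the change from compound 2 to compound 3 is expected to move the read-out by a number 2 percentage points higher from compound 2 to compound 3 (within the scatter), that is, no further than the scatter allows, in no firm direction. Compound 3 is therefore estimated to give 70%, with a range from 55% to 85%.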

Compound 3, a percentage reported as inhibition, at one concentration (the size of the read-out at that concentration, not a potency): 79%
Compound 3: the middle estimate sits 9 percentage points below what was measured, within the range that was stated.
By their numbers in this assay, from the lowest: compounds 2, 1 and 3 (each within the scatter of the next, the first and the last beyond it).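

In this assay, among these compounds, phenyl in place of cyclohexyl on an aromatic carbon gives a number 11 percentage points higher from compound 2 to compound 3 (beyond the scatter), a modest step, and this is the first direct sign that the read-out responds to a change at this position: an aromatic ring and a non-aromatic ring, each of six carbons, are not interchangeable here. Hydrogen in place of methoxy on an aromatic carbon of the phenyl ring gives a number 4 percentage points higher from compound 1 to compound 3 (within the scatter), so among the compounds shown, the methoxy group makes no difference that can be told apart from the scatter. Nothing available explains why phenyl and cyclohexyl differ at this position.

The compounds shown leave open whether a pyridine ring or an open chain such as n-butyl would fit this position as well as phenyl does, and whether an amine or a carboxylic acid on the phenyl ring would shift the read-out. Each number also gives the size of the effect at a single concentration, so how the potencies of these compounds compare remains open.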